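Cyclobutylamide Replaces Methylamide on a Shared Urea Core

A few compounds are considered here, and "the series" means these few. Any claim that something is new, unique, unknown or untested is made for them only; others in the source may bear on it.

Of the compounds shown here, three built on one shared core have been measured. Compound 1 `CC(NC(=O)c1cccc(-c2ccc(NC(=O)Nc3ccc(Cl)c(C(F)(F)F)c3)cc2)c1)c1ccccc1` gives 5670 nM in a functional assay on HepG2 cells (Homo sapiens) for inhibition, read by MTT assay, with a stated time of 120 h; on this read-out lower numbers stand for stronger inhibition and higher numbers for weaker inhibition. Compound 2 `CNC(=O)/C(C)=C/c1ccc(NC(=O)Nc2ccc(Cl)c(C(F)(F)F)c2)cc1` gives 44300 nM in this assay, the higher of the two numbers, and the nearest number, that of compound 1, lies beyond the scatter below it. Compound 3 `C/C(=C\c1ccc(NC(=O)Nc2ccc(Cl)c(C(F)(F)F)c2)cc1)C(=O)N1CC(C)OC(C)C1` reaches only the limit of > 50000 nM in this assay. The step of an at least 1.1-fold higher number from compound 2 to compound 3 (0.05 log units; that floor lies within the scatter) is therefore only a floor, due to the limit of > 50000 nM in this assay, at which 1 of the 3 values shown sits.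

Compound 4 `O=C(/C=C/c1ccc(NC(=O)Nc2ccc(Cl)c(C(F)(F)F)c2)cc1)NC1CCC1` awaits measurement in this assay. It differs from compound 2 by 2-(cyclobutylcarbamoyl)ethenyl in place of 2-(methylcarbamoyl)prop-1-en-1-yl on an aromatic carbon. Among the compounds with values here, the one measured step that touches the same part of the molecule, an at least 1.1-fold higher number from compound 2 to compound 3 (0.05 log units; that floor lies within the scatter), swapped the group on the amide nitrogen and gave a number no better than that of compound 2. A change of similar kind is expected here, so the step of a 1.1-fold lower number from compound 2 to compound 4 (0.04 log units; within the scatter) is expected to stay within the scatter. Compound 4 is therefore estimated at 40000 nM, between 15000 nM and 100000 nM.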

Compound 4, half-maximal inhibitory concentration: 7510 nM
Estimate against measurement, compound 4: 5.3-fold (0.73 log units) above; the measured number lies below the stated range.
By their numbers in this assay, from the lowest: compounds 1 and 4 (each within the scatter of the next); then compound 2. At a limit, above all of these: compound 3.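

In this assay, this change, on an aromatic carbon para to a large group, moves the number by more than the scatter: a 5.9-fold lower number from compound 2 to compound 4 (0.77 log units; beyond the scatter). The earlier step on this side chain could give only a floor, because compound 3 stands at a limit: the limit of > 50000 nM in this assay, at which 1 of the 4 values shown sits.

The new step therefore gives the first readable size for a change in this side chain, but it bundles two differences: 2-(cyclobutylcarbamoyl)ethenyl carries a cyclobutyl ring on the amide nitrogen where 2-(methylcarbamoyl)prop-1-en-1-yl has a methyl, and it also lacks the methyl on the chain. The compounds shown cannot tell which of these two differences goes with the lower number, since no compound here has one without the other. Going by these compounds, how an amine or a longer carbon chain on the amide nitrogen would read in this assay also stays open.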